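Chloro to bromo on the aromatic carbon: expected effect

The compounds below may be only part of what the source reports. "The series", "measured", "known", "first", "only" and "open" are said of these compounds alone.

Compound 1 `CN1C(=O)C2(C(C#N)=C(N)Oc3cc4oc(-c5ccccc5)cc(=O)c4c(O)c32)c2ccccc21` gives > 50000 nM in a functional assay on A549 cells (Homo sapiens) for antiproliferative activity, read by MTT assay, with a stated time of 48 h (a lower number here means a stronger inhibitor, a higher number a weaker inhibitor), and this value is a limit of the assay rather than a number. Compound 2 `Cc1ccc2c(c1)C1(C(=O)N2C)C(C#N)=C(N)Oc2cc3oc(-c4ccccc4)cc(=O)c3c(O)c21` gives 7060 nM in this assay. Compound 3 `CN1C(=O)C2(C(C#N)=C(N)Oc3cc4oc(-c5ccccc5)cc(=O)c4c(O)c32)c2cc(Cl)ccc21` gives 4720 nM in this assay, the lowest of the two numbers shown, with compound 2 nearest; the step of a 1.5-fold lower number from compound 2 to compound 3 (0.17 log units; within the scatter) is within the scatter, while an at least 10-fold lower number from compound 1 to compound 3 (1.02 log units; beyond the scatter) is large. Compound 4 `CN1C(=O)C2(C(C#N)=C(N)Oc3cc4oc(-c5ccccc5)cc(=O)c4c(O)c32)c2cc(Br)ccc21` differs from compound 3 by bromo in place of chloro on an aromatic carbon. The bearing steps are an at least 10-fold lower number from compound 1 to compound 3 (1.02 log units; beyond the scatter) and a 1.5-fold lower number from compound 2 to compound 3 (0.17 log units; within the scatter), the latter showing that swapping one substituent for another at this carbon moved little. For compound 4 no step beyond the scatter is expected, a 1.2-fold lower number from compound 3 to compound 4 (0.07 log units; within the scatter). The estimate for compound 4 in this assay is 4000 nM, with a range from 1800 nM to 9000 nM.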

Compound 4, half-maximal inhibitory concentration: 3150 nM
Compound 4: the middle estimate sits 1.3-fold (0.10 log units) above what was measured; low and high end bracket the measured number.
By their numbers in this assay, from the lowest: compounds 4, 3 and 2 (each within the scatter of the next, the first and the last beyond it). At a limit, above all of these: compound 1.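

In this assay chloro and bromo at this aromatic carbon cannot be told apart (a 1.5-fold lower number from compound 3 to compound 4 (0.18 log units; within the scatter)). Bromo does separate from methyl (a 2.2-fold lower number from compound 2 to compound 4 (0.35 log units; beyond the scatter)), which chloro did not, and the distance from hydrogen is now seen for a third substituent (an at least 15-fold lower number from compound 1 to compound 4 (1.20 log units; beyond the scatter)). Compound 1 stands at a limit of the assay, so that last step is a bound only: the limit of > 50000 nM in this assay, at which 1 of the 4 values shown sits.

Open, from the compounds shown here alone, is whether fluoro or iodo at this carbon would stay in the same range. An amine or a carboxylic acid there is also untested in the compounds shown.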